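The compounds below may be only part of what the source reports. "The series", "measured", "known", "first", "only" and "open" are said of these compounds alone.

Measured compounds:
compound 1 `COc1cc(/C=C2\CCC/C(=C\c3ccccc3[N+](=O)[O-])C2=O)cc(Br)c1OC` — 6.24 ug/mL
compound 2 `COc1cc(/C=C2\CCC/C(=C\c3ccc([N+](=O)[O-])cc3)C2=O)cc(Br)c1O` — 16.8 ug/mL

Among the compounds with values here, in a functional assay on SK-N-MC cells (Homo sapiens) for cytotoxicity, read by MTT assay (a higher number here means a weaker inhibitor, a lower number a stronger inhibitor), compound 2 gives the higher of the two numbers; compound 1 gives 6.24 ug/mL, a lower number beyond the scatter, although no single-change step links the pair. Compound 3 `COc1cc(/C=C2\CCC/C(=C\c3ccc([N+](=O)[O-])cc3)C2=O)cc(Br)c1OC` is the next candidate, not yet measured. It differs from compound 2 by methyl in place of hydrogen on an oxygen on an aromatic ring. Within the data shown here, no step of this kind has been measured in this assay. Compound 1, which also carries the methoxy, gives 6.24 ug/mL, so for compound 3 a modestly lower number than compound 2 is expected, about a 1.8-fold lower number from compound 2 to compound 3 (0.25 log units; within the scatter). Compound 3 is estimated at 9.5 ug/mL, range 4.5 ug/mL to 20 ug/mL.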

Compound 3, half-maximal inhibitory concentration: 9.86 ug/mL
The estimate for compound 3 lay 1.0-fold (0.02 log units) below the measured number, and the stated range covers the measured number.
By their numbers in this assay, from the lowest: compounds 1, 3 and 2 (each within the scatter of the next, the first and the last beyond it).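

In this assay the hydroxy to methoxy change on the aromatic ring gives a 1.7-fold lower number from compound 2 to compound 3 (0.23 log units; within the scatter) and so cannot be told from repeat scatter at this oxygen. Taking 4-nitrophenyl in place of 2-nitrophenyl gives a 1.6-fold higher number from compound 1 to compound 3 (0.20 log units; within the scatter) and is likewise within the scatter. Each single step is thus unresolved, although the printed values of compound 1 and compound 2 lie beyond the scatter of each other.

As far as these compounds go, whether an ethyl or longer chain on that oxygen, or an amine or carboxylic acid in place of the nitro group, would give a resolved step stays open. No measurement on hand speaks to the cause of either step.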